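A few compounds are considered here, and "the series" means these few. Any claim that something is new, unique, unknown or untested is made for them only; others in the source may bear on it.

In an ADME assay on PA-1 cells (Homo sapiens) for cytotoxicity, read by MTT assay, with a stated time of 72 h (a higher number here means a weaker inhibitor, a lower number a stronger inhibitor), compound 2 `COc1ccc(C2=C(c3cc(OC)c(OC)c(OC)c3)C(=O)C(O)C2)cc1Cl` gives > 100 ug/mL, which is a limit of the assay and not a number. Compound 1 `COc1ccc(C2=C(c3cc(OC)c(OC)c(OC)c3)C(=O)C(O)C2)cc1` gives < 1 ug/mL, also a limit. Among the compounds with values here, the one measured step bearing on what follows is an at least 100-fold higher number from compound 1 to compound 2 (2.00 log units; beyond the scatter), large and beyond the scatter, with chloro in place of hydrogen on an aromatic carbon. Compound 3 `COc1ccc(C2=C(c3cc(OC)c(OC)c(OC)c3)C(=O)C(O)C2)cc1F` differs from compound 2 by fluoro in place of chloro on an aromatic carbon. With chloro gone, much of that loss is expected to reverse, so the expected change is an at least 20-fold lower number from compound 2 to compound 3 (1.30 log units; beyond the scatter), a large step towards a lower number. For compound 3 the estimated value is 5 ug/mL, with an expected range of 0.5 ug/mL to 60 ug/mL.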

Compound 3, half-maximal inhibitory concentration: > 100 ug/mL
Compound 3: a limit, no number; the forecaster's own chance of this, stated with the estimate: 35%; at least 20-fold (1.30 log units) between middle value and limit.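

In this assay compound 3 gives > 100 ug/mL, which is a limit of the assay and not a number. Fluoro in place of hydrogen at this position gives an at least 100-fold higher number from compound 1 to compound 3 (2.00 log units; beyond the scatter) in that assay, so the large loss is not confined to chloro. The step from compound 2 to compound 3 cannot be read, as both values are limits.

Still open, as far as these compounds go, is whether any group on this carbon is tolerated, as a hydroxyl, a methyl or an amine here could show. The limits also leave unknown which halogen costs more.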